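The compounds below may be only part of what the source reports. "The series", "measured", "known", "first", "only" and "open" are said of these compounds alone.

Notes on the series in an ADME assay on cells (kidney, Cercopithecidae) for cytotoxicity; a higher number here means a weaker inhibitor, a lower number a stronger inhibitor. Compound 1 (`N#Cc1cn(COC(CO)CO)c2ncnc(N)c12`) gives > 100000 nM, which is a limit of the assay and not a number. Compound 2 (`NC(=O)c1cn(COC(CO)CO)c2ncnc(N)c12`) gives > 100000 nM, again only a limit. Among the measured compounds shown here, the one measured step is a step that the two limits leave unreadable from compound 1 to compound 2, and its size cannot be read. What the series offers so far is the limit of > 100000 nM in this assay, at which 2 of the 2 values shown sit.

Compound 3 (`N/C(=N\O)c1cn(COC(CO)CO)c2ncnc(N)c12`) changes compound 2 on an aromatic carbon of the five-membered aromatic ring: a group of 4 heavy atoms (1 carbon, 2 nitrogen, 1 oxygen; no ring) in place of a group of 3 heavy atoms (1 carbon, 1 nitrogen, 1 oxygen; no ring), on an aromatic carbon.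

For the measured compounds named here, the only guide is compound 2 with its limit of > 100000 nM, so no shift beyond the scatter is expected in this assay, in either direction. The estimated step is a number no higher from compound 2 to compound 3 (the limit leaves the size open). For compound 3 the expected value is 100000 nM, with an estimated range of 40000 nM to 200000 nM, and a report as a limit again is the likeliest outcome.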

Compound 3, half-maximal inhibitory concentration: > 100000 nM
Compound 3: only a limit was reported; the forecaster's own chance of this, stated with the estimate: 85%; the middle value lies on the limit itself.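

Among the compounds shown here, compound 1, compound 2 and compound 3 are all reported only as limits, so no step among them can be read. The compounds shown leave open whether the group on the aromatic carbon changes the value in this assay at all, as the series offers only this: the limit of > 100000 nM in this assay, at which 3 of the 3 values shown sit.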